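Halogen swap on the benzyl arm of a bombesin receptor agonist

The compounds below may be only part of what the source reports. "The series", "measured", "known", "first", "only" and "open" are said of these compounds alone.

Compounds measured so far:
compound 1, `O=C(O)c1ccccc1-c1ccc(CCc2ncc(CC3CCC3)[nH]2)cc1`, 588 nM;
compound 2, `O=C(O)c1ccccc1-c1ccc(CCc2ncc(Cc3ccccc3F)[nH]2)cc1`, 177 nM.

In an in vitro functional assay on cells for agonist activity at Bombesin receptor subtype-3 (Homo sapiens), read by luminescence and calcium flux (a higher number here means that more compound is needed for the effect, a lower number that less compound is needed), compound 2 gives the lowest of the two numbers, and its nearest neighbour is compound 1, a step of a 3.3-fold lower number from compound 1 to compound 2 (0.52 log units; beyond the scatter). Compound 3, `O=C(O)c1ccccc1-c1ccc(CCc2ncc(Cc3ccc(Cl)cc3)[nH]2)cc1`, differs from compound 2 in one place: 4-chlorophenyl in place of 2-fluorophenyl on a saturated chain carbon bound to an aromatic carbon. For the measured compounds named here, no measured step changes one aryl halide for another; the only step available, a 3.3-fold lower number from compound 1 to compound 2 (0.52 log units; beyond the scatter), swaps a cyclobutyl for a 2-fluorophenyl and so speaks to the worth of an aromatic ring at this position rather than to the halogen or its place on the ring. Going by the values given here, with that step as the only guide, the move to compound 3 is expected to stay close to compound 2 in this assay, a step of a 1.2-fold lower number from compound 2 to compound 3 (0.07 log units; within the scatter), likely within the scatter. Compound 3 is therefore estimated at 150 nM, with a range from 50 nM to 500 nM.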

Compound 3, half-maximal effective concentration: 2290 nM
Estimate against measurement, compound 3: 15-fold (1.18 log units) below; the measured number lies above the stated range.
By their numbers in this assay, from the lowest: compound 2; then compound 1; then compound 3.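

At this position, on a saturated chain carbon bound to an aromatic carbon, an aromatic ring does not by itself secure the lower number: in this assay the swap of 2-fluorophenyl for 4-chlorophenyl gives a 13-fold higher number from compound 2 to compound 3 (1.11 log units; beyond the scatter) and leaves the result on the wrong side of cyclobutyl, with a 3.9-fold higher number from compound 1 to compound 3 (0.59 log units; beyond the scatter) overall. The two aryl groups have equal heavy-atom counts and the same ring, so the outcome at this position depends on the halogen, on its place on the ring, or on both. No measured evidence bears on the origin of this difference.

Halogen and ring position change together here, so their shares cannot be separated. As far as these compounds go, how a plain phenyl, or a methoxy group in place of the halogen, would read at this position remains open.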